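Removing a chloro group from the benzamide of compound 2

The source may hold more compounds than are shown below. What is called first, only, known or untested is meant among the compounds shown, and "the series" means these compounds.

Compound 1, `O=C(Nc1cccc(-n2cc(-c3ccncc3)c(-c3ccc(Cl)c(O)c3)n2)c1)Nc1ccc(Cl)c(Cl)c1`: in a functional assay on HOP-92 cells (Homo sapiens) for inhibition, read by sulforhodamine B assay, with a stated time of 48 h (on this read-out higher numbers stand for weaker inhibition of growth and lower numbers for stronger inhibition of growth), compound 1 gives 679 nM.
Compound 2, `COc1cc(-c2nn(-c3cccc(NC(=O)c4ccc(Cl)c(C(F)(F)F)c4)c3)cc2-c2ccncc2)ccc1Cl`: in this assay compound 2 gives 665 nM.

Both measured compounds share a core carrying a pyridyl group and a chlorophenyl group, and differ in the linker and the outer aryl ring. The two numbers lie within the usual scatter of each other, so neither compound 1 nor compound 2 can be called the stronger or the weaker inhibitor of growth on what has been measured.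

Compound 3, `COc1cc(-c2nn(-c3cccc(NC(=O)c4cccc(C(F)(F)F)c4)c3)cc2-c2ccncc2)ccc1Cl`, is the next compound. It differs from compound 2 in one place: hydrogen in place of chloro on an aromatic carbon.

For the measured compounds named here, no pair of measured compounds differs in exactly this way, so there is no directly comparable step to lean on. The loss of a single chloro from the outer ring is a small change, and the step from compound 2 to compound 3 is expected to be modest, a little towards weaker inhibition, a 1.5-fold higher number from compound 2 to compound 3 (0.18 log units; within the scatter), roughly at the edge of the scatter. For compound 3 in this assay the expected value is 1000 nM, with a range from 400 nM to 2500 nM.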

Compound 3, concentration for 50% growth inhibition: 555 nM
Compound 3: middle estimate off by 1.8-fold (0.26 log units), on the high side, within the range that was stated.
By their numbers in this assay, from the lowest: compounds 3, 2 and 1 (each within the scatter of the next).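

In this assay, going from the 4-chloro-3-(trifluoromethyl)phenyl ring to the 3-(trifluoromethyl)phenyl ring gives a 1.2-fold lower number from compound 2 to compound 3 (0.08 log units; within the scatter), so at this position, ortho to the trifluoromethyl group, hydrogen in place of chloro has no effect that can be told from the scatter. For the compounds shown here, this is the first step that isolates a single change, since compound 1 and compound 2 differ in both the linker and the outer aryl ring, and it shows that the growth inhibition seen with compound 2 does not depend on this chloro. The data shown offer no measurement that would explain why the chloro can go without a visible effect.

The compounds shown compare only chloro and hydrogen at this position, so it remains open whether an amine, a methoxy group or a carboxylic acid there would also leave the number within the scatter. From the compounds shown here alone, it is also open whether the trifluoromethyl group can give way to a nitrile or a methyl group, and whether losing a chloro from the outer ring of compound 1 would read the same way.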